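From a Small Acyl Group to a Large One

A few compounds are considered here, and "the series" means these few. Any claim that something is new, unique, unknown or untested is made for them only; others in the source may bear on it.

Going by the values given here, in an assay on SK-BR-3 cells for inhibition of Aromatase (Homo sapiens) (a higher number here means a weaker inhibitor, a lower number a stronger inhibitor), compound 3 `CC(=O)Nc1ccc([N+](=O)[O-])cc1OCc1ccccc1` gives 1180 nM, the only plain number among the three measured compounds. Compound 1 `O=C(Nc1ccc([N+](=O)[O-])cc1OCc1ccccc1)c1ccccc1` reaches only the limit of the assay, giving > 25000 nM. Compound 2 `O=C(Nc1ccc([N+](=O)[O-])cc1OCc1ccccc1)C1CCCCC1` likewise stops at the limit, giving > 25000 nM. Both of those results sit at the limit of > 25000 nM in this assay, at which 2 of the 3 values shown sit, so compound 3 stands alone with a readable number, and the step that the two limits leave unreadable from compound 1 to compound 2 cannot be sized.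

Compound 4 `O=C(Nc1ccc([N+](=O)[O-])cc1OCc1ccccc1)c1ccc([N+](=O)[O-])cc1` differs from compound 3 in one place: 4-nitrophenyl in place of methyl on a carbonyl carbon. The measured steps that bear on this change run in the opposite direction: an at least 21-fold lower number from compound 1 to compound 3 (1.32 log units; beyond the scatter) and an at least 21-fold lower number from compound 2 to compound 3 (1.32 log units; beyond the scatter). In both, shrinking the group on the carbonyl carbon to methyl gave a large drop in the number, so enlarging it again from methyl to 4-nitrophenyl is expected to raise the number strongly, probably back to the limit, a step of about a 21-fold higher number from compound 3 to compound 4 (1.33 log units; beyond the scatter). Compound 4 is therefore estimated at 25000 nM, with a range from 5000 nM to 100000 nM.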

Compound 4, half-maximal inhibitory concentration: > 25000 nM
Compound 4 gave a limit, no number; the forecaster's own chance of this, stated with the estimate: 75%; the middle value lies on the limit itself.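

Putting 4-nitrophenyl in place of methyl on the carbonyl carbon gives an at least 21-fold higher number from compound 3 to compound 4 (1.32 log units; beyond the scatter), so the loss seen with phenyl and cyclohexyl also appears with a ring that carries a nitro group. Compound 4 gives > 25000 nM, which is a limit of the assay and not a number, and the steps to it from compound 1 and compound 2 cannot be read, so any effect of the nitro group on the phenyl ring stays hidden. Of the four compounds, only the one with methyl gives a readable number, and all three ring-bearing compounds end at the same place: the limit of > 25000 nM in this assay, at which 3 of the 4 values shown sit.

The compounds shown leave open how the number changes between methyl and the ring groups, which an ethyl group or a longer chain such as propyl could test. From the compounds shown here alone, it also remains open whether another small group on this carbonyl carbon, such as an amine or methoxy, would match or improve on methyl.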